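The source may report more compounds than this note shows. Statements on the series, on what has been measured and on what is new or still open speak of the compounds shown alone.

In a functional assay on T47D cells (Homo sapiens) for cytotoxicity, read by MTT assay, with a stated time of 48 h (a lower number here means a stronger inhibitor, a higher number a weaker inhibitor), compound 1 (`COc1ccc(NC(=S)N/N=C\c2ccnc3ccccc23)cc1`) gives 1360 nM and compound 2 (`S=C(N/N=C\c1ccnc2ccccc12)Nc1cccnc1`) gives 1100 nM as its result. These two values lie within the usual scatter of each other, so compound 2 cannot be told apart from compound 1 on these numbers. Compound 3 (`CCc1ccc(NC(=S)N/N=C\c2ccnc3ccccc23)cc1`) keeps the shared core of compound 2 but carries 4-ethylphenyl in place of pyridin-3-yl on an amide-type nitrogen. For the measured compounds named here, only one measured step bears on this change, namely the exchange of 4-methoxyphenyl for pyridin-3-yl at the same nitrogen. That exchange gave a 1.2-fold lower number from compound 1 to compound 2 (0.09 log units; within the scatter) in this assay and so produced no shift beyond the scatter. Going by the values given here, no measured compound yet carries 4-ethylphenyl, and a single step is thin evidence, so the expected range has to stay wide. Even so, no step beyond the scatter is expected, in either direction. The estimate therefore means a 1.1-fold higher number from compound 2 to compound 3 (0.06 log units; within the scatter) as the expected step. For compound 3 the estimated value is 1250 nM (range 550 nM to 2800 nM).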

Compound 3, half-maximal inhibitory concentration: 1280 nM
For compound 3 the middle estimate is 1.0-fold (0.01 log units) below the measured one; measured number inside the range.
By their numbers in this assay, from the lowest: compounds 2, 3 and 1 (each within the scatter of the next).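

Exchanging pyridin-3-yl for 4-ethylphenyl on the amide-type nitrogen gives a 1.2-fold higher number from compound 2 to compound 3 (0.07 log units; within the scatter) in this assay and so shows that a ring of carbon only, carrying an ethyl group, fits this place as well as the ring with a hetero atom. The second new comparison, ethyl in place of methoxy on an aromatic carbon, gives a 1.1-fold lower number from compound 1 to compound 3 (0.03 log units; within the scatter) and adds something the first pair could not show: the substituent on the benzene-type ring can also be exchanged without a step beyond the scatter. For these three compounds, then, every change at this nitrogen stays within the scatter, but nothing available here explains why the numbers stay so close.

All the groups shown at this nitrogen are six-membered aromatic rings, so it remains open how an open-chain group such as butyl, or a saturated ring such as cyclohexyl, would behave there. It is also unknown whether a ring carrying an amine or a carboxylic acid in place of ethyl or methoxy would move the number beyond the scatter.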